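The source may hold more compounds than are shown below. What is called first, only, known or untested is meant among the compounds shown, and "the series" means these compounds.

Measured in a functional assay on MDA-MB-231 cells (Homo sapiens) for antiproliferative activity, read by MTT assay, with a stated time of 48 h; on this read-out higher numbers stand for weaker inhibition and lower numbers for stronger inhibition:
- Compound 1 `COc1ccc(N(C)c2ccnc(Cl)n2)cc1`: 2820 nM
- Compound 2 `COc1ccc(N(C)c2ccnc(Cl)n2)cc1Cl`: 1380 nM
- Compound 3 `COc1ccc(N(C)c2ccnc(Cl)n2)cc1OCCCBr`: 1280 nM

Compound 2 stands level with compound 3, as a 1.1-fold lower number from compound 2 to compound 3 (0.03 log units; within the scatter) shows, while the gap on the other side is larger: a 2.0-fold lower number from compound 1 to compound 2 (0.31 log units; beyond the scatter). Compound 4 `COc1ccc(N(C)c2ccnc(Cl)n2)cc1OCC[Se]C#N` has not been measured. It changes one place of compound 2: a group of 6 heavy atoms (3 carbon, 1 nitrogen, 1 oxygen, 1 selenium; no ring) in place of one chlorine atom, on an aromatic carbon.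

The nearest measured swap puts a 3-bromopropoxy chain in place of that chloro, and it gave a 1.1-fold lower number from compound 2 to compound 3 (0.03 log units; within the scatter). Putting that chain in place of hydrogen gave a modest 2.2-fold lower number from compound 1 to compound 3 (0.34 log units; beyond the scatter). For the measured compounds named here, no measured compound contains selenium, so this evidence is limited. this assay is therefore expected to show a small step towards a lower number, possibly none beyond the scatter. The expected change is a 1.5-fold lower number from compound 2 to compound 4 (0.19 log units; within the scatter). The estimate for compound 4 is 900 nM, with an expected range of 200 nM to 2500 nM.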

Compound 4, half-maximal inhibitory concentration: 2750 nM
Compound 4: the middle estimate sits 3.1-fold (0.49 log units) below what was measured; measured number above the stated range.
By their numbers in this assay, from the lowest: compounds 3, 2, 4 and 1 (each within the scatter of the next, the first and the last beyond it).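

On this aromatic carbon, the chain of compound 4 behaves differently from the 3-bromopropoxy chain in this assay, with a modest step (a 2.1-fold higher number from compound 3 to compound 4 (0.33 log units; beyond the scatter)). Measured against hydrogen (a 1.0-fold lower number from compound 1 to compound 4 (0.01 log units; within the scatter)) and against chloro (a 2.0-fold higher number from compound 2 to compound 4 (0.30 log units; within the scatter)), the selenium-bearing chain shows no step beyond the scatter. An oxygen-linked chain here therefore does not lower the number by itself, and no available evidence explains the difference. On these data alone, it remains open whether a longer chain carrying the same selenium and nitrile end, or a chain ending in an amine, would behave like compound 3 or like compound 4.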